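Cyclopropyl replaces 1-methyl-1H-pyrazol-4-yl on an amide-type nitrogen

The source may report more compounds than this note shows. Statements on the series, on what has been measured and on what is new or still open speak of the compounds shown alone.

Compound 2 (`CNC(=O)c1cc(C(=O)Nc2cnn(C)c2)cc2c1OC[C@H]2c1ccccc1`) gives 3.5 in a physicochemical assay for lipophilicity, at pH 7.4; a higher number here means a more lipophilic compound, a lower number a more polar compound. For the measured compounds named here, compound 1 (`CNC(=O)c1cc(C(=O)NC2CC2)cc2c1OC[C@H]2c1cccc2[nH]ccc12`) gives 3.5 in this assay, which leaves the two level within the usual scatter, so compound 2 stands at the same place as the only other measured compound.

Compound 3 (`CNC(=O)c1cc(C(=O)NC2CC2)cc2c1OC[C@H]2c1ccccc1`) keeps the rest of compound 2 and changes a single group, with cyclopropyl in place of 1-methyl-1H-pyrazol-4-yl on an amide-type nitrogen. Going by the values given here, changing one group at a time is a simple way to compare molecules, but no measured pair shows this change alone, so the forecast rests on thin data. Compound 1 also carries cyclopropyl and gives 3.5, so no large step is expected. A small downward step is expected, a number 0.40 log units lower from compound 2 to compound 3 (beyond the scatter). For compound 3 the estimated value is 3.1, with an expected range from 2.7 to 3.5.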

Compound 3, distribution coefficient: 3.6
Estimate against measurement, compound 3: 0.50 log units below; the whole stated range lies below it.
By their numbers in this assay, from the lowest: compounds 1, 2 and 3 (each within the scatter of the next).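

In this assay, putting cyclopropyl in place of 1-methyl-1H-pyrazol-4-yl on the amide-type nitrogen gives a number 0.10 log units higher from compound 2 to compound 3 (within the scatter), so this read-out does not separate the two groups at this position, although they differ in ring size, heavy atoms and hydrogen-bond acceptors. Compound 3 also gives a comparison at a second place, where phenyl in place of 1H-indol-4-yl on a saturated ring carbon gives a number 0.10 log units higher from compound 1 to compound 3 (within the scatter), so this change also stays inside the scatter. Nothing on record offers an explanation for either result.

Going by these compounds, it remains open how a group of another kind on the amide-type nitrogen, such as a carboxylic acid or a chain carrying an amine, would read in this assay. Among the compounds shown each change appears only once, so whether either holds on a different background also remains open.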